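This account rests on a few compounds, and the source may have more. Where it says the series, first, only, none or still open, it means among the compounds named here.

Compound 2 `CN(C)CCCOc1c(OCc2ccccc2)cc2oc(-c3ccccc3)cc(=O)c2c1O` is the lower of the two numbers measured in a functional assay on BCG823 cells (Homo sapiens) for antiproliferative activity, read by MTT assay, with a stated time of 48 h (on this read-out lower numbers stand for stronger inhibition and higher numbers for weaker inhibition), where compound 2 gives 5500 nM. Within the data shown here, its only neighbour is compound 1 `CN1CCN(CCCCOc2c(OCc3ccccc3)cc3oc(-c4ccccc4)cc(=O)c3c2O)CC1`, which in this assay gives 7200 nM; the step of a 1.3-fold lower number from compound 1 to compound 2 (0.12 log units; within the scatter) is within the scatter, so no order between these two can be claimed.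

Compound 3 `CCN(CC)CCCCOc1c(OCc2ccccc2)cc2oc(-c3ccccc3)cc(=O)c2c1O` has not yet been measured. It differs from compound 2 by (diethylamino)methyl in place of dimethylamino on a saturated chain carbon, three bonds along the chain from an oxygen on an aromatic ring. Among the measured compounds shown here, the one measured step that bears on this change is the exchange at the same chain carbon between compound 1 and compound 2, a 1.3-fold lower number from compound 1 to compound 2 (0.12 log units; within the scatter), which was within the scatter. Nothing else in the set touches the chain end, so the only basis is that one step. Compound 3 is therefore expected to show no step beyond the scatter, a change of no change at the digits printed from compound 2 to compound 3 (within the scatter) in this assay. The estimate for compound 3 in this assay is 5500 nM, with a range from 2500 nM to 12000 nM.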

Compound 3, half-maximal inhibitory concentration: 4200 nM
The estimate for compound 3 lay 1.3-fold (0.12 log units) above the measured number; low and high end bracket the measured number.
By their numbers in this assay, from the lowest: compounds 3, 2 and 1 (each within the scatter of the next).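

With compound 3, the 4-(diethylamino)butyl chain can be set against the chain of compound 1 at the same length, so the amine alone is exchanged, a comparison the earlier pair did not offer. In this assay, the exchange of 4-methylpiperazin-1-yl for diethylamino gives a 1.7-fold lower number from compound 1 to compound 3 (0.23 log units; within the scatter), and the open-chain amine and the ring amine cannot be told apart on this read-out. The second change, 3-(dimethylamino)propyl to 4-(diethylamino)butyl, alters both the chain and the groups on its nitrogen and gives a 1.3-fold lower number from compound 2 to compound 3 (0.12 log units; within the scatter), so this larger end group also produces no step that can be read, and no information is at hand to explain these numbers.

The compounds shown do not separate chain length from the amine, since no two of them carry the same amine on chains of different length, as a 3-(diethylamino)propyl chain set against compound 3 would. As far as these compounds go, it also remains open whether a morpholine, a shorter chain, or a carboxylic acid in place of the amine at the chain end would move the number beyond the scatter.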